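The source may hold more compounds than are shown below. What is called first, only, known or untested is meant among the compounds shown, and "the series" means these compounds.

Series values in a functional assay on DU-145 cells (Homo sapiens) for inhibition, read by trypan blue exclusion, with a stated time of 96 h; a lower number here means a stronger inhibitor of growth, a higher number a weaker inhibitor of growth:
- compound 1 `COc1cc(/C=C(/Sc2ccc(Br)cc2)C(=O)c2ccc(Br)cc2)ccc1O` gives 1000 nM
- compound 2 `O=C(O)c1ccc(C(=O)/C(=C\c2ccc(Br)c([N+](=O)[O-])c2)SCc2ccc(Cl)cc2)cc1` gives < 1000 nM (a limit)
- compound 3 `CN(C)c1ccc(/C=C(/SCc2ccccc2Cl)C(=O)c2ccc(Cl)cc2)cc1` gives > 100000 nM (a limit)

Going by the values given here, compound 1 holds the only exact number of the three, and the other two entries are limits. Compound 4 `O=C(/C(=C\c1ccc(F)cc1F)Sc1ccc(Br)cc1)c1ccc(Br)cc1` keeps the rest of compound 1 and carries 2,4-difluorophenyl in place of 4-hydroxy-3-methoxyphenyl on a double-bonded chain carbon bound to a double-bonded chain carbon. Among the compounds with values here, no measured pair isolates this change, so the only anchor is compound 1 at 1000 nM. In this assay a modest loss of growth inhibition is expected, slightly beyond the usual scatter. The expected change runs a 2.5-fold higher number from compound 1 to compound 4 (0.40 log units; beyond the scatter). For compound 4 the estimated value is 2500 nM with an expected range from 500 nM to 15000 nM.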

Compound 4, concentration for 50% growth inhibition: 1000 nM
Beside the measured number, compound 4's estimate is 2.5-fold (0.40 log units) above it; the range from low to high includes it.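

In this assay, putting 2,4-difluorophenyl in place of 4-hydroxy-3-methoxyphenyl on a double-bonded chain carbon bound to a double-bonded chain carbon gives no change at the digits printed from compound 1 to compound 4 (within the scatter). Going by these compounds alone, this is the first one-place comparison, and it shows that at this position, on the core of compound 1, the hydroxy and methoxy groups can give way to two fluorines without a readable shift in growth inhibition. Nothing shown gives a reason for this.

Going by these compounds, whether an unsubstituted phenyl or a pyridine ring would be tolerated here remains open. Also open, on these data alone, is whether this swap reads the same once other parts of the core change.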